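A few compounds are considered here, and "the series" means these few. Any claim that something is new, unique, unknown or untested is made for them only; others in the source may bear on it.

Compound 1 `CC(C)(C)c1ccc(C(=O)/C=C/c2ccc([N+](=O)[O-])o2)cc1`: > 100000 nM
Compound 2 `O=C(/C=C/c1ccc([N+](=O)[O-])s1)c1ccc(-n2ccnc2)cc1`: 42700 nM
Compound 3 `O=C(/C=C/c1ccc([N+](=O)[O-])o1)c1cccc(Br)c1`: 68800 nM

The three compounds were tested in an ADME assay on Vero cells (Chlorocebus sabaeus) for cytotoxicity, read by resazurin assay, with a stated time of 72 h; on this read-out lower numbers stand for higher toxicity in this test and higher numbers for lower toxicity in this test. There, compound 1 reads > 100000 nM, which is a limit of the assay and not a number. Compound 4 `CCCCc1ccc(C(=O)/C=C/c2ccc([N+](=O)[O-])o2)cc1` has butyl in place of tert-butyl on an aromatic carbon. Among the compounds with values here, no measured pair of compounds shows what this change does. Compound 2 at 42700 nM and compound 3 at 68800 nM do give numbers, so a modest move towards that region is expected. The estimated step of an at least 1.5-fold lower number from compound 1 to compound 4 (0.18 log units; that floor lies within the scatter) points to lower numbers in this assay. For compound 4 the expected value is 65000 nM, with an estimated range of 28000 nM to 130000 nM.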

Compound 4, half-maximal cytotoxic concentration: 75700 nM
Beside the measured number, compound 4's estimate is 1.2-fold (0.07 log units) below it, within the range that was stated.
By their numbers in this assay, from the lowest: compounds 2, 3 and 4 (each within the scatter of the next). At a limit, above all of these: compound 1.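

In this assay, butyl in place of tert-butyl on an aromatic carbon, para to a large group, gives an at least 1.3-fold lower number from compound 1 to compound 4 (0.12 log units; that floor lies within the scatter). The two chains hold the same atoms, joined differently, yet compound 4 carries a number where compound 1 carries only a limit. The step is therefore a floor, and its full size cannot be read: the limit of > 100000 nM in this assay, at which 1 of the 4 values shown sits.

The compounds shown leave open whether a propyl chain, a longer chain or an amine at this position would also give a number in this assay.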